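Replacing the hydroxy of compound 3 with an ethyl chain

A few compounds are considered here, and "the series" means these few. Any claim that something is new, unique, unknown or untested is made for them only; others in the source may bear on it.

Of the compounds shown here, three sharing one core have been tested in an ADME assay on HeLa cells (Homo sapiens) for cytotoxicity, read by sulforhodamine B assay, with a stated time of 48 h, tested at 10 uM; on this read-out higher numbers stand for more inhibition at the one concentration tested (going by the name of the read-out) and lower numbers for less inhibition. Compound 1 `CCCCc1cn(C(c2ccccc2)c2cc3cc(Br)ccc3nc2OC)nn1` gives -2.87%. Compound 2 `CCCCCCCc1cn(C(c2ccccc2)c2cc3cc(Br)ccc3nc2OC)nn1` gives 9.7%. Compound 3 `COc1nc2ccc(Br)cc2cc1C(c1ccccc1)n1cc(CCCO)nn1` gives 11.3%, the highest of the three numbers, though the gap to compound 2 is within the scatter, while the gap to compound 1 is beyond it.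

Compound 4 `CCCCCc1cn(C(c2ccccc2)c2cc3cc(Br)ccc3nc2OC)nn1` has not yet been measured. The difference from compound 3 is ethyl in place of hydroxy on a saturated chain carbon, three bonds along the chain from an aromatic carbon.

Within the data shown here, two measured steps bear on this. The step of a number 1.6 percentage points higher from compound 2 to compound 3 (within the scatter) went the opposite way, hydroxy in place of butyl at the same place, and was within the scatter. The step of a number 12.6 percentage points higher from compound 1 to compound 2 (beyond the scatter) lengthened the chain and was modest. Compound 4 carries a chain longer than in compound 1 and shorter than in compound 2, so its number is expected between those two values.

For compound 4 in this assay a value of 4% is therefore estimated, in the range -8% to 16%, which means an expected step of a number 7.3 percentage points lower from compound 3 to compound 4 (within the scatter), not beyond the scatter.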

Compound 4, a percentage reported as inhibition, at one concentration (the size of the read-out at that concentration, not a potency): -9.81%
Compound 4: middle estimate off by 13.8 percentage points, on the high side; measured number below the stated range.
By their numbers in this assay, from the lowest: compounds 4 and 1 (each within the scatter of the next); then compounds 2 and 3 (each within the scatter of the next).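

In this assay the end of the chain at this position proves to matter: ethyl in place of hydroxy, which turns 3-hydroxypropyl into pentyl, gives a number 21.1 percentage points lower from compound 3 to compound 4 (beyond the scatter) even though compound 2 and compound 3 lay within the scatter of each other. Chain length alone also reads unevenly, since going from butyl to pentyl gives a number 6.9 percentage points lower from compound 1 to compound 4 (within the scatter) while going from heptyl to pentyl gives a number 19.5 percentage points lower from compound 2 to compound 4 (beyond the scatter) and places compound 4 with compound 1 rather than with compound 2. Nothing available here offers an explanation for these steps.

Still open, on these data alone, is whether an amine or a carboxylic acid at the end of the propyl chain would read like the hydroxy of compound 3 or like the plain chain of compound 4. A chain longer than heptyl also remains untested among these compounds, so it is unclear whether the number would keep moving with length.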